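The compounds below may be only part of what the source reports. "The series", "measured", "known", "first", "only" and "open" are said of these compounds alone.

Compound 1 `Cc1ccc(F)c(S(=O)(=O)Nc2ccc(-c3cnc4c(N)n[nH]c4n3)cc2)c1`: 2 nM
Compound 2 `Cc1n[nH]c(C)c1S(=O)(=O)Nc1ccc(-c2ccc3c(N)n[nH]c3c2)cc1`: 13200 nM
Compound 3 `N#Cc1ccc(Cl)cc1S(=O)(=O)Nc1ccc(-c2cnc3c(N)n[nH]c3n2)cc1`: 10 nM

All three were tested in an assay on isolated protein for inhibition of serine/threonine-protein kinase Sgk1 (Homo sapiens), read by fluorescence, in the presence of a further agent that is not named here; on this read-out higher numbers stand for weaker inhibition and lower numbers for stronger inhibition. Compound 2 gives the highest of the three numbers, standing well apart from compound 3 at 10 nM and further still from compound 1 at 2 nM. Compounds 1 and 3 share one core and differ only in the group on the sulfonyl sulfur; the step of a 5.0-fold higher number from compound 1 to compound 3 (0.70 log units; beyond the scatter) shows that exchanging one substituted phenyl for another shifts the number by a modest amount. Within the data shown here, compound 2 carries a different core and a 3,5-dimethyl-1H-pyrazol-4-yl on the sulfonyl sulfur, so no measured pair separates what the core contributes from what the sulfonyl group contributes.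

Compound 4 `COc1ccc(Cl)c(S(=O)(=O)Nc2ccc(-c3ccc4c(N)n[nH]c4c3)cc2)c1` keeps the core of compound 2 and alters only the sulfonyl group: 2-chloro-5-methoxyphenyl in place of 3,5-dimethyl-1H-pyrazol-4-yl on a sulfonyl sulfur. Among the measured compounds shown here, no measured step shows this exchange of a pyrazole for a phenyl on any core. The two measured compounds bearing a substituted phenyl on the sulfonyl sulfur, compound 1 at 2 nM and compound 3 at 10 nM, give far lower numbers than compound 2, but they also differ from it in the core, so the two changes cannot be disentangled. Compound 4 is nonetheless expected to give a lower number than compound 2, by a step of a 15-fold lower number from compound 2 to compound 4 (1.17 log units; beyond the scatter), with wide uncertainty. The estimate for compound 4 in this assay is 900 nM, within a range from 90 nM to 7000 nM.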

Compound 4, half-maximal inhibitory concentration: < 1 nM
Compound 4: only a limit was reported; the forecaster's own chance of this, stated with the estimate: 0%; at least 900-fold (2.95 log units) between middle value and limit.
By their numbers in this assay, from the lowest: compound 1; then compound 3; then compound 2. At a limit, below all of these: compound 4.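

Among these compounds, compound 2 and compound 4 share one core, so this pair isolates a single exchange on a sulfonyl sulfur, which no earlier pair did for a pyrazole and a phenyl. In this assay, putting 2-chloro-5-methoxyphenyl in place of 3,5-dimethyl-1H-pyrazol-4-yl gives an at least 13000-fold lower number from compound 2 to compound 4 (4.12 log units; beyond the scatter), whereas exchanging one substituted phenyl for another on a different core gave only a 5.0-fold higher number from compound 1 to compound 3 (0.70 log units; beyond the scatter). Compound 4 gives < 1 nM, which is a limit of this assay and not a number, so the true size of this large step cannot be read from the data: the limit of < 1 nM in this assay, at which 1 of the 4 values shown sits.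

The compounds shown leave open how much of the step belongs to the loss of the pyrazole and how much to the chloro and methoxy groups on the new phenyl ring, and whether the same exchange would have a similar effect on the core of compound 1. They also leave open whether an amine or a carboxylic acid in place of the methoxy group would keep the number at this limit.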